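Swapping Piperidin-1-yl for a Hydroxy Amino Chain

The source may hold more compounds than are shown below. What is called first, only, known or untested is meant among the compounds shown, and "the series" means these compounds.

In an in vitro ADME assay on microsomes from liver (Rattus norvegicus) for metabolic stability (a higher number here means faster removal of the compound, a lower number slower removal), compound 3 `CC(C)NC(=O)[C@H]1CC[C@@H](n2/c(=N/C(=O)c3ccc(F)cc3)[nH]c3ccc(CN4CCCCC4)cc32)CC1` gives 451 mL.min-1.g-1. Compound 1 `CC(C)NC(=O)[C@H]1CC[C@@H](n2/c(=N/C(=O)c3ccccc3)[nH]c3ccc(CN4CCCCC4)cc32)CC1` gives 389 mL.min-1.g-1, and the step of fluoro in place of hydrogen, a 1.2-fold higher number from compound 1 to compound 3 (0.06 log units; within the scatter), leaves the two level at the high end of the numbers measured. Compound 2 `CC(C)NC(=O)[C@H]1CC[C@@H](n2/c(=N/C(=O)c3ccc(F)cc3)[nH]c3ccc(CN4CC(C(C)(C)O)C4)cc32)CC1` reports only a limit of the assay, < 14 mL.min-1.g-1.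

Compound 4 `CC(C)NC(=O)[C@H]1CC[C@@H](n2/c(=N/C(=O)c3ccc(F)cc3)[nH]c3ccc(CNCC(C)(C)O)cc32)CC1` departs from compound 3 in a single place: (2-hydroxy-2-methylpropyl)amino in place of piperidin-1-yl on a saturated chain carbon bound to an aromatic carbon. There, (2-hydroxy-2-methylpropyl)amino stands in place of piperidin-1-yl on a saturated chain carbon bound to an aromatic carbon. The fluoro group stays, so the fluoro step has no bearing on this change. The step that does bear on it also concerns piperidin-1-yl at this place, where it replaces 3-(1-hydroxy-1-methylethyl)azetidin-1-yl: an at least 32-fold higher number from compound 2 to compound 3 (1.50 log units; beyond the scatter). On these data alone, its full size stays open, since one end of it rests on (the limit of < 14 mL.min-1.g-1 in this assay, at which 1 of the 3 values shown sits). The group entering compound 4 also carries a hydroxy group but has no ring, so only part of that large step is expected to carry over in reverse. In this assay the expected change is large and beyond the scatter, estimated as a 14-fold lower number from compound 3 to compound 4 (1.15 log units; beyond the scatter). For compound 4 the estimated value is 32 mL.min-1.g-1, with an expected range from 12 mL.min-1.g-1 to 120 mL.min-1.g-1.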

Compound 4, intrinsic clearance in microsomes: 68 mL.min-1.g-1
The estimate for compound 4 lay 2.1-fold (0.33 log units) below the measured number, within the range that was stated.
By their numbers in this assay, from the lowest: compound 4; then compounds 1 and 3 (each within the scatter of the next). At a limit, below all of these: compound 2.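

In this assay, the change shows that this place on a saturated chain carbon bound to an aromatic carbon does not need a ring for the number to fall: a 6.6-fold lower number from compound 3 to compound 4 (0.82 log units; beyond the scatter) comes with (2-hydroxy-2-methylpropyl)amino, a group with no ring and the same number of heavy atoms as the piperidin-1-yl it replaces. The two groups that carry a hydroxy group are not equivalent here either, since an at least 4.8-fold higher number from compound 2 to compound 4 (0.68 log units; beyond the scatter) separates the open chain from 3-(1-hydroxy-1-methylethyl)azetidin-1-yl. Compound 2 stands at a limit of the assay, and the full size of that second step stays open: the limit of < 14 mL.min-1.g-1 in this assay, at which 1 of the 4 values shown sits.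

The compounds shown do not separate the loss of the piperidine ring from the arrival of the hydroxy group and the extra nitrogen-bound hydrogen, as both changes occur together in compound 4. A (2-methylpropyl)amino group, the same chain without its hydroxy group, or a 4-hydroxypiperidin-1-yl group, which keeps the ring and adds the hydroxy group, would pull these two parts of the change apart.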